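This account rests on a few compounds, and the source may have more. Where it says the series, first, only, none or still open, it means among the compounds named here.

Compound 1 `COc1cccc(Oc2c(NS(=O)(=O)c3ccc(C(C)(C)C)cc3)ncnc2OCCO)c1` gives 160 nM in an assay on cells (Endothelial cell) for binding affinity to Endothelin-1 receptor (Sus scrofa); a lower number here means a stronger inhibitor, a higher number a weaker inhibitor. Compound 2 `COc1cccc(Oc2c(NS(=O)(=O)c3ccc(C(C)(C)C)cc3)ncnc2OCCOc2ccccc2)c1` gives 65 nM in this assay; the change from compound 1 is phenyl in place of hydrogen on the oxygen on a saturated carbon, and the step is a 2.5-fold lower number from compound 1 to compound 2 (0.39 log units; beyond the scatter). Among the compounds with values here, compound 2 thus stands at the lower of the two numbers measured so far, with compound 1 as its only neighbour, separated by a step beyond the scatter.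

Compound 3 `COCCOc1ncnc(NS(=O)(=O)c2ccc(C(C)(C)C)cc2)c1Oc1cccc(OC)c1` is not yet measured in this assay. Relative to compound 2 the change is methyl in place of phenyl on an oxygen on a saturated carbon; cut one bond further out it reads phenoxy to methoxy. Within the data shown here, the only measured step that bears on it ran the other way and was modest. Compound 3 is therefore expected to give back part of the gain seen in a 2.5-fold lower number from compound 1 to compound 2 (0.39 log units; beyond the scatter), while a methyl rather than a hydrogen remains on that oxygen. Compound 3 is expected to show a higher number, a modest step of a 1.8-fold higher number from compound 2 to compound 3 (0.27 log units; within the scatter). For compound 3 in this assay the estimate is 120 nM, with a range of 55 nM to 260 nM.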

Compound 3, half-maximal inhibitory concentration: 92 nM
For compound 3 the middle estimate is 1.3-fold (0.12 log units) above the measured one; low and high end bracket the measured number.
By their numbers in this assay, from the lowest: compounds 2, 3 and 1 (each within the scatter of the next, the first and the last beyond it).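

On the oxygen on a saturated carbon, methyl in place of phenyl gives a 1.4-fold higher number from compound 2 to compound 3 (0.15 log units; within the scatter) in this assay and so cannot be told apart from the phenyl of compound 2 on these numbers. Methyl in place of hydrogen gives a 1.7-fold lower number from compound 1 to compound 3 (0.24 log units; within the scatter) and is equally unresolved, while a 2.5-fold lower number from compound 1 to compound 2 (0.39 log units; beyond the scatter) remains the only step here beyond the scatter, so compound 3 sits inside that modest gap without being separated from either end. Nothing measured here accounts for these steps.

As far as these compounds go, how a longer chain, a benzyl group, an amine or a carboxylic acid in place of the methyl on that oxygen would read in this assay remains open. Also open, from the compounds shown here alone, is whether a substituted phenyl would move the number further than the phenyl of compound 2 does.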